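The compounds below may be only part of what the source reports. "The series", "measured", "known", "first", "only" and "open" are said of these compounds alone.

Compound 1 `Fc1cccc(-c2nc(Nc3ccccc3)c3cc(F)ccc3n2)c1` is the reference point of this short series. In a functional assay on U2OS cells (Homo sapiens) for cytotoxicity, read by MTT assay, with a stated time of 48 h (a higher number here means a weaker inhibitor, a lower number a stronger inhibitor), compound 1 gives 47600 nM, the second highest of the three numbers recorded. Compound 2 `Fc1cccc(Nc2nc(-c3cccc(F)c3)nc3ccc(F)cc23)c1` gives 49600 nM and lies nearest, the step being a 1.0-fold higher number from compound 1 to compound 2 (0.02 log units; within the scatter). Compound 3 `Fc1cccc(-c2nc(Nc3ccc(Cl)cc3)c3cc(F)ccc3n2)c1` gives 38400 nM, the furthest of the set, with a 1.2-fold lower number from compound 1 to compound 3 (0.09 log units; within the scatter). Between the two substituted anilines the step is a 1.3-fold lower number from compound 2 to compound 3 (0.11 log units; within the scatter). All three measured values therefore sit together, and nothing among them separates one compound from another.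

Compound 4 `Fc1cccc(-c2nc(Nc3ccccc3Cl)c3cc(F)ccc3n2)c1` is the next member, differing from compound 1 by chloro in place of hydrogen on an aromatic carbon. Among the measured compounds shown here, the one measured step that bears on this change is the chloro introduced at another place of the same ring in compound 3, which gave a 1.2-fold lower number from compound 1 to compound 3 (0.09 log units; within the scatter), a movement inside the scatter. For the measured compounds named here, no measured step exceeds the scatter, so no step beyond it is expected here either; the expected step is a 1.1-fold lower number from compound 1 to compound 4 (0.03 log units; within the scatter). For compound 4 the estimate in this assay is 44000 nM, with a range from 22000 nM to 88000 nM.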

Compound 4, half-maximal inhibitory concentration: > 50000 nM
Compound 4 ended at the assay's limit (the forecaster's own chance of this, stated with the estimate: 15%); middle value at least 1.1-fold (0.05 log units) away from the limit.
By their numbers in this assay, from the lowest: compounds 3, 1 and 2 (each within the scatter of the next). At a limit, above all of these: compound 4.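

In this assay, the reading for compound 4, with its 2-chlorophenyl group, is a limit of the assay and not a number: the limit of > 50000 nM in this assay, at which 1 of the 4 values shown sits. The floors of the two readable steps, an at least 1.0-fold higher number from compound 1 to compound 4 (0.02 log units; that floor lies within the scatter) and an at least 1.3-fold higher number from compound 3 to compound 4 (0.11 log units; that floor lies within the scatter), lie within the scatter, so neither chloro in place of hydrogen at this place nor 2-chlorophenyl in place of 4-chlorophenyl is shown to exceed it, although the limit leaves the true size of each step open. The remaining step, a number no lower from compound 2 to compound 4 (the limit leaves the size open), cannot be read.

As far as these compounds go, how far the number for compound 4 lies past the limit remains open. Also open, from the compounds shown here alone, is whether an amine or a methoxy group in place of this chloro would give a step beyond the scatter.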